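This account rests on a few compounds, and the source may have more. Where it says the series, first, only, none or still open, it means among the compounds named here.

Measured compounds in an assay on VSM-A10 cells for antagonist activity at Endothelin-1 receptor (Rattus norvegicus); on this read-out higher numbers stand for weaker inhibition and lower numbers for stronger inhibition:
compound 1 `Cc1noc(N(CC(=O)O)S(=O)(=O)c2ccc(N)cc2)c1C` — > 32000 nM
compound 2 `Cc1noc(NS(=O)(=O)c2cccc3c(Cl)cccc23)c1C` — 24000 nM
compound 3 `Cc1noc(NS(=O)(=O)c2ccc(F)cc2)c1C` — 1000 nM

The value of compound 1 is a limit of this assay and not a number; the same limit appears in the limit of > 32000 nM in this assay, at which 1 of the 3 values shown sits. Among the two numbers, compound 2 stands highest. Among the compounds with values here, compound 3 differs from compound 2 in more than one place, so no single step connects them; its value is lower than that of compound 2, and the gap between the two is beyond the scatter.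

The unmeasured compound 4 `Cc1noc(NS(=O)(=O)c2cccc3c(C(C)(C)O)cccc23)c1C` keeps the shared core of compound 2 and changes only one position: 1-hydroxy-1-methylethyl in place of chloro on an aromatic carbon. Within the data shown here, no measured pair in this set carries the same change, so there is no step to lean on, and no measured property of the entering group is known here. The series offers only compound 2 as a starting point, and its value sits close to the limit of this assay.

Compound 4 is therefore expected to stay near compound 2, with at most a modest move downward; the expected step is a 1.6-fold lower number from compound 2 to compound 4 (0.20 log units; within the scatter). For compound 4 the estimated value in this assay is 15000 nM, with a range from 4000 nM to 45000 nM.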

Compound 4, half-maximal inhibitory concentration: 2890 nM
Beside the measured number, compound 4's estimate is 5.2-fold (0.72 log units) above it; the whole stated range lies above it.
By their numbers in this assay, from the lowest: compound 3; then compound 4; then compound 2. At a limit, above all of these: compound 1.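

Within the data shown here, at this aromatic carbon, ortho to a fused ring and meta to a fused ring, the change from chloro to 1-hydroxy-1-methylethyl gives the first single-place step: in this assay it reads an 8.3-fold lower number from compound 2 to compound 4 (0.92 log units; beyond the scatter). The earlier compounds shown here gave no step at all, so they could not show that this position responds to substitution, and this result shows that the read-out moves beyond the scatter when chloro is replaced here. The only limit among the compounds shown belongs to compound 1, and it is a limit rather than a number: the limit of > 32000 nM in this assay, at which 1 of the 4 values shown sits.

One step cannot tell whether the change in this assay follows the hydroxyl, the two methyl groups or simply the loss of chloro, and the entering group's hydrogen-bond donor and acceptor are counted here but not tested separately. On these data alone, a plain isopropyl group, a methoxy group, an amine or a carboxylic acid at this same position would separate these readings, and how this position relates to compound 3 remains open, as that compound differs from compound 4 in more than one place.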